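The compounds below may be only part of what the source reports. "The series", "measured", "known", "first", "only" and "open" are said of these compounds alone.

Measured compounds in a functional assay on NCI-H460 cells (Homo sapiens) for antiproliferative activity, read by WST assay, with a stated time of 72 h; on this read-out higher numbers stand for weaker inhibition and lower numbers for stronger inhibition:
Compound 1 `Nc1n/c(=N\CCCCc2ccccc2)nc(N)c2c1ncn2Cc1ccccc1` gives 18800 nM.
Compound 2 `CCCCCCCCCCCCCCCCCC/N=c1\nc(N)c2ncn(Cc3ccccc3)c2c(N)n1` gives 5400 nM.
Compound 3 `CCCCCCCCCCCCCC/N=c1\nc(N)c2ncn(Cc3ccccc3)c2c(N)n1` gives 6750 nM.

Compound 3 stands second highest of the three numbers; its nearest neighbour is compound 2, within the scatter, and compound 1 lies furthest from it, beyond the scatter. Compound 4 `CCCCCCCC/N=c1\nc(N)c2ncn(Cc3ccccc3)c2c(N)n1` differs from compound 3 by hydrogen in place of hexyl on a saturated chain carbon, eight bonds along the chain from a double-bonded nitrogen. Going by the values given here, two measured steps bear on this change along the chain. The step of a 2.8-fold lower number from compound 1 to compound 3 (0.44 log units; beyond the scatter) was modest and beyond the scatter, while the step of a 1.3-fold higher number from compound 2 to compound 3 (0.10 log units; within the scatter) was within it. Hydrogen in place of hexyl is therefore expected to raise the number in this assay somewhat, possibly not beyond the scatter. For compound 4 a value of 10000 nM is estimated, with a range from 5000 nM to 20000 nM, which corresponds to an expected step of a 1.5-fold higher number from compound 3 to compound 4 (0.17 log units; within the scatter).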

Compound 4, half-maximal inhibitory concentration: 7450 nM
Compound 4: middle estimate off by 1.3-fold (0.13 log units), on the high side; the range from low to high includes it.
By their numbers in this assay, from the lowest: compounds 2, 3 and 4 (each within the scatter of the next); then compound 1.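

In this assay, hydrogen in place of hexyl gives a 1.1-fold higher number from compound 3 to compound 4 (0.04 log units; within the scatter), and hydrogen in place of decyl gives a 1.4-fold higher number from compound 2 to compound 4 (0.14 log units; within the scatter), so shortening the chain at this place leaves compounds 2, 3 and 4 all within the scatter. Butyl in place of phenyl still gives a 2.5-fold lower number from compound 1 to compound 4 (0.40 log units; beyond the scatter), so the separation from the phenyl-bearing chain persists with this shorter alkyl chain. No supporting evidence is available to explain these results. The compounds shown leave open whether chains shorter than that of compound 4 would stay within the scatter, and how an amine or a carboxylic acid in place of hexyl would read.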